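The source may hold more compounds than are shown below. What is called first, only, known or untested is meant among the compounds shown, and "the series" means these compounds.

Working notes on the series. Compound 1 `O=C(N/N=C/c1cccc(O)c1O)c1ccc(-c2nc3ccccc3s2)cc1` was examined in an assay on isolated protein for inhibition of Maltase-glucoamylase (Homo sapiens), with a stated time of 15 min (a higher number here means a weaker inhibitor, a lower number a stronger inhibitor), and gives 11200 nM, a weak result. Compound 2 `COc1ccc(/C=N/NC(=O)c2ccc(-c3nc4ccccc4s3)cc2)cc1O` shares the core of compound 1 and differs only in the substituted phenyl ring on the carbon with a double bond to nitrogen; in this assay compound 2 is recorded as "not active" (no number reported), so no number can be placed against it and it stands only as the weaker of the two measured compounds. Compound 3 `O=C(N/N=C/c1ccncc1)c1ccc(-c2nc3ccccc3s2)cc1` is the next member to be measured. Its change from compound 2 is pyridin-4-yl in place of 3-hydroxy-4-methoxyphenyl on a carbon with a double bond to nitrogen. For the measured compounds named here, no step between measured compounds is available for this change. Given that compound 1 is already weak in this assay and compound 2 gives no number at all, compound 3 is expected to sit in the same weak region, with a fair chance that this assay again reports only a limit rather than a number. The estimate for compound 3 in this assay is 25000 nM, within the range 8000 nM to 80000 nM.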

Compound 3, half-maximal inhibitory concentration: "not active" (no number reported)
For compound 3 the study gives words and no number; there is nothing to compare the estimate with.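

Compound 2 and compound 3 both stand without a number in this assay, so no step can be read between them. No evidence on hand bears on this result. The compounds shown leave open whether pyridin-4-yl or 3-hydroxy-4-methoxyphenyl on this carbon gives any measurable inhibition in this assay.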